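A few compounds are considered here, and "the series" means these few. Any claim that something is new, unique, unknown or untested is made for them only; others in the source may bear on it.

Compound 1, `CC(C)(C)CCNc1ccc([N+](=O)[O-])cc1S(N)(=O)=O`, in an assay on HEK293 cells for inhibition of solute carrier family 12 member 2 (Homo sapiens), read by fluorescence, with a stated time of 30 min, tested at 100 uM (a higher number here means a stronger effect of the compound at the concentration tested, a lower number a weaker effect), compound 1 gives 14.5%.
Compound 2, `CC(C)(C)CCNc1ccc(C(=O)O)cc1S(N)(=O)=O`, in this assay compound 2 gives 5.1%.

Within the data shown here, compound 2 stands lowest of the two numbers measured so far; its nearest neighbour is compound 1, and the step of a number 9.4 percentage points lower from compound 1 to compound 2 (within the scatter) lies within the scatter, so the two values cannot be ordered. Compound 3, `CNS(=O)(=O)c1cc(C(=O)O)ccc1NCCC(C)(C)C`, differs from compound 2 by methyl in place of hydrogen on a sulfonamide nitrogen. Among the measured compounds shown here, the only measured step, a number 9.4 percentage points lower from compound 1 to compound 2 (within the scatter), concerns carboxy in place of nitro on an aromatic carbon and does not touch the sulfonamide nitrogen, so no measured step bears on the change from compound 2 to compound 3. With nothing in the data to argue for a shift in either direction, compound 3 is expected to land close to compound 2, with an estimated step of a number 0.9 percentage points higher from compound 2 to compound 3 (within the scatter), within the scatter. Compound 3 is therefore estimated at 6% in this assay, in a range from -10% to 22%.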

Compound 3, a percentage reported as inhibition, at one concentration (the size of the read-out at that concentration, not a potency): 2.6%
Beside the measured number, compound 3's estimate is 3.4 percentage points above it; the measured number falls inside the stated range.
By their numbers in this assay, from the lowest: compounds 3, 2 and 1 (each within the scatter of the next, the first and the last beyond it).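

Among these compounds, the step of a number 2.5 percentage points lower from compound 2 to compound 3 (within the scatter) is the first reading at the sulfonamide nitrogen, and in this assay it does not separate methyl from hydrogen at this place. The change thus adds one carbon to the sulfamoyl group without a shift that the assay can resolve, though that reading rests on a single pair with a carboxy group on the shared core, at one concentration, where compound 2 gives 5.1% and compound 3 gives 2.6%. Nothing available explains this reading or ties it to any property of the methyl group.

The compounds shown leave open whether an ethyl or benzyl group, or a second methyl, on the same nitrogen would read alike. They also leave open whether methylsulfamoyl in place of sulfamoyl would behave the same way with the nitro group of compound 1 on the core.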